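Replacing the Diethylamino Group of Compound 3 with Hydroxy

The compounds below may be only part of what the source reports. "The series", "measured", "known", "first", "only" and "open" are said of these compounds alone.

In a functional assay on HeLa cells (Homo sapiens) for antiproliferative activity, read by MTT assay, with a stated time of 48 h (on this read-out lower numbers stand for stronger inhibition and higher numbers for weaker inhibition), compound 3 (`CCN(CC)CCCn1c(N)c(-c2nc3ccccc3[nH]2)c2nc(C#N)c(C#N)nc21`) gives 3150 nM as the lowest number of the series, and compound 2 (`CN(C)CCCn1c(N)c(-c2nc3ccccc3[nH]2)c2nc(C#N)c(C#N)nc21`) gives 25900 nM as the nearest number. Compound 1 (`CN1CCN(CCn2c(N)c(-c3nc4ccccc4[nH]3)c3nc(C#N)c(C#N)nc32)CC1`) reads > 50000 nM as a limit of the assay. Compound 4 (`N#Cc1nc2c(-c3nc4ccccc4[nH]3)c(N)n(CCCO)c2nc1C#N`) carries hydroxy in place of diethylamino on a saturated chain carbon (hydroxy in place of diethylamino on a saturated chain carbon, three bonds along the chain from an aromatic nitrogen). The two other chain ends both sit higher than compound 3, shown by an 8.2-fold lower number from compound 2 to compound 3 (0.91 log units; beyond the scatter) and an at least 15-fold lower number from compound 1 to compound 3 (1.20 log units; beyond the scatter) and, between those two, by an at least 1.9-fold lower number from compound 1 to compound 2 (0.28 log units; that floor lies within the scatter) as the remaining comparison. Hydroxy itself is untested here, so a weakening of about the modest size seen for compound 2 is expected, namely a 4.8-fold higher number from compound 3 to compound 4 (0.68 log units; beyond the scatter) in this assay as the estimated step. Compound 4 is therefore estimated at 15000 nM with an expected range from 3500 nM to 50000 nM around it.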

Compound 4, half-maximal inhibitory concentration: > 50000 nM
Compound 4: only a limit was reported (the forecaster's own chance of this, stated with the estimate: 25%); middle value at least 3.3-fold (0.52 log units) from the limit.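

With hydroxy in place of diethylamino at this chain end, there is an at least 15-fold higher number from compound 3 to compound 4 (1.20 log units; beyond the scatter) in this assay and so the diethylamino group cannot be swapped for hydroxy here without a large loss. The comparison with the dimethylamino chain end gives only an at least 1.9-fold higher number from compound 2 to compound 4 (0.28 log units; that floor lies within the scatter) and so says little. Compound 4 reads only as a limit, as does compound 1, so the step between them cannot be read: the limit of > 50000 nM in this assay, at which 2 of the 4 values shown sit.

Still open, going by these compounds, is whether the nitrogen or the ethyl groups of the diethylamino end matter more. A pyrrolidine at the same place or a 4-(diethylamino)butyl chain would help separate these.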